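The compounds below may be only part of what the source reports. "The series", "measured", "known", "first", "only" and "open" are said of these compounds alone.

Compound 1 `O=C(Nc1ccccc1Cl)c1nccc2ccccc12`, in a functional assay on NUGC-3 cells (Homo sapiens) for inhibition, read by sulforhodamine B assay, with a stated time of 48 h (on this read-out lower numbers stand for stronger inhibition of growth and higher numbers for weaker inhibition of growth), gives > 10000 nM; compound 2 `O=C(Nc1cccc(C(F)(F)F)c1)C1c2ccccc2CCN1C(=O)c1ccc(Cl)cc1`, in this assay gives > 10000 nM.

For compound 1 the reported figure is only a limit, > 10000 nM, not a number. Compound 2 likewise stops at a limit, > 10000 nM. Compound 1 thus stands at the limit of > 10000 nM in this assay, at which 2 of the 2 values shown sit, the edge of what the read-out reports. Compound 3 `COc1ccccc1NC(=O)c1nccc2ccccc12` differs from compound 1 by methoxy in place of chloro on an aromatic carbon. Going by the values given here, no measured step between compounds exists here, so the expected step that the limit leaves unreadable from compound 1 to compound 3 is none beyond the scatter. Compound 3 is estimated at about 15000 nM, within 5000 nM to 50000 nM, most likely again as a limit.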

Compound 3, concentration for 50% growth inhibition: > 10000 nM
Compound 3 gave a limit, no number; the forecaster's own chance of this, stated with the estimate: 85%; the middle value lies beyond the limit too.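

Compound 1 and compound 3 both stop at a limit, so methoxy in place of chloro gives no readable step: the limit of > 10000 nM in this assay, at which 3 of the 3 values shown sit.

The compounds shown leave open what structure would give growth inhibition that the read-out reports as a number.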